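Swapping the methoxy for trifluoromethyl: agonist efficacy outlook

The source may hold more compounds than are shown below. What is called first, only, known or untested is meant among the compounds shown, and "the series" means these compounds.

Measured so far:
compound 1, `CS(=O)(=O)c1ccc(Cl)cc1NCC1=NCCN1`: 91%
compound 2, `COc1ccc(S(C)(=O)=O)c(NCC2=NCCN2)c1`: 102%

In a functional assay for agonist activity at Alpha-1A adrenergic receptor (Homo sapiens) (on this read-out lower numbers stand for smaller maximal responses and higher numbers for larger maximal responses), compound 2 gives 102%, the highest of the two numbers, and its nearest neighbour is compound 1, which gives 91%. Within the data shown here, the one measured step, a number 11 percentage points higher from compound 1 to compound 2 (beyond the scatter), was modest but beyond the scatter.

Compound 3, `CS(=O)(=O)c1ccc(C(F)(F)F)cc1NCC1=NCCN1`, has not yet been tested. It differs from compound 2 in a single place: trifluoromethyl in place of methoxy on an aromatic carbon.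

Among the measured compounds shown here, no measured step shows a trifluoromethyl entering, so the only guide is that the single change seen at this carbon moved this assay by a number 11 percentage points higher from compound 1 to compound 2 (beyond the scatter). A step of comparable size, in either direction, is the most that can be expected. Compound 3 is therefore estimated at 90% in this assay, within 72% to 108%, an expected step of a number 12 percentage points lower from compound 2 to compound 3 (beyond the scatter).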

Compound 3, largest response reached (reported as maximum), in percent of the reference or control that the assay uses: 95%
For compound 3 the middle estimate is 5 percentage points below the measured one, and the stated range covers the measured number.
By their numbers in this assay, from the lowest: compounds 1, 3 and 2 (each within the scatter of the next, the first and the last beyond it).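

Placing trifluoromethyl on this carbon, para to a methylsulfonyl group, gives a number 7 percentage points lower from compound 2 to compound 3 (within the scatter) when it replaces methoxy and a number 4 percentage points higher from compound 1 to compound 3 (within the scatter) when it replaces chloro. So in this assay the maximal response tolerates a larger group with no hydrogen-bond acceptor, and compound 3 cannot be told apart from either compound 1 or compound 2, although those two differ from each other beyond the scatter. No available measurement explains why these three groups give such similar responses.

Going by these compounds, it remains open whether an amine, a carboxylic acid or a longer chain on this carbon would keep the maximal response in the same range. These numbers also leave open how much of each compound is needed to reach that response.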